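Removing the 3,4-dichlorobenzyl group from compound 2

The compounds below may be only part of what the source reports. "The series", "measured", "known", "first", "only" and "open" are said of these compounds alone.

In a functional assay on cells (T-cell line, Homo sapiens) for inhibition (a higher number here means a weaker inhibitor, a lower number a stronger inhibitor), compound 1 (`COc1cccc(CCCN2CCC(COC(c3ccccc3)c3ccccc3)CC2)c1`) gives 1500 nM and compound 2 (`Clc1ccc(CCCN2CCC(COC(c3ccccc3)c3ccccc3)CC2)cc1Cl`) gives 2200 nM. For the measured compounds named here, the only measured step, a 1.5-fold higher number from compound 1 to compound 2 (0.17 log units; within the scatter), lies within the scatter, so compound 2 stands level with compound 1 on these numbers.

Compound 3 (`CCN1CCC(COC(c2ccccc2)c2ccccc2)CC1`) differs from compound 2 as follows: hydrogen in place of 3,4-dichlorobenzyl on a saturated chain carbon, two bonds along the chain from an amine nitrogen in a ring. What remains on the amine nitrogen in a ring is a short chain with no aromatic ring.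

The measured step bears on this only loosely. It exchanges 3,4-dichlorophenyl for 3-methoxyphenyl, and an aromatic ring stays at the end of the chain in both compounds. Going by the values given here, no measured compound lacks that ring, so the data give no direct size for its loss. The change here is much larger than the measured one, and a move toward weaker inhibition in this assay is expected, though with wide uncertainty. The expected step is a 3.6-fold higher number from compound 2 to compound 3 (0.56 log units; beyond the scatter). For compound 3 the estimate is 8000 nM, with an expected range of 2500 nM to 30000 nM.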

Compound 3, half-maximal inhibitory concentration: > 20000 nM
Compound 3 was reported as a limit (the forecaster's own chance of this, stated with the estimate: 20%); middle value at least 2.5-fold (0.39 log units) from the limit.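

In this assay compound 3 is reported only as a limit, not as a number: the limit of > 20000 nM in this assay, at which 1 of the 3 values shown sits. Even so, the loss of the 3,4-dichlorobenzyl group gives an at least 9.0-fold higher number from compound 2 to compound 3 (0.95 log units; beyond the scatter), and the loss of the 3-methoxybenzyl group gives an at least 13-fold higher number from compound 1 to compound 3 (1.12 log units; beyond the scatter). Exchanging one substituted aromatic ring for the other at the end of the chain left compound 1 and compound 2 level within the scatter, whereas the short chain with no aromatic ring in compound 3 stands clearly apart from both, so among these three compounds, inhibition at this position goes with an aromatic ring at the end of the chain.

From the compounds shown here alone, with compound 3 held at a limit, the full size of the loss stays unknown, and three compounds cannot show how much of the end group is needed. Open too, going by these compounds, is whether an unsubstituted phenyl or a cyclohexyl ring at the end of the chain would keep inhibition at the level of compound 1 and compound 2, and how a shorter or longer chain would fare.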